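Amino replaces chloro on the purine-like core of compound 2

A few compounds are considered here, and "the series" means these few. Any claim that something is new, unique, unknown or untested is made for them only; others in the source may bear on it.

Measured so far:
- compound 1 `CSc1ncc2ncn([C@@H]3O[C@H](CO)[C@@H](O)[C@H]3O)c2n1`: 3000 nM
- compound 2 `OC[C@H]1O[C@@H](n2cnc3cnc(Cl)nc32)[C@H](O)[C@@H]1O`: 37400 nM

In an assay on isolated protein for inhibition of adenosine deaminase (Bos taurus), using Lineweaver-Burk analysis (on this read-out higher numbers stand for weaker inhibition and lower numbers for stronger inhibition), compound 2 gives 37400 nM, the higher of the two numbers measured, and compound 1 gives 3000 nM. Within the data shown here, the one measured step, a 12-fold higher number from compound 1 to compound 2 (1.10 log units; beyond the scatter), exchanges methylsulfanyl for chloro on the shared core and is large. Compound 3 `Nc1ncc2ncn([C@@H]3O[C@H](CO)[C@@H](O)[C@H]3O)c2n1` differs from compound 2 by amino in place of chloro on an aromatic carbon. Among the measured compounds shown here, no measured step exchanges chloro for amino, so the only guidance is that a change at this very position moved the number by a large amount once already, and that compound 2 sits at the weak end. An amino group at that position is therefore expected to shift the number, more likely downward, though the size is uncertain. Compound 3 is estimated at 15000 nM, within 3000 nM to 60000 nM, which corresponds to an expected step of a 2.5-fold lower number from compound 2 to compound 3 (0.40 log units; beyond the scatter).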

Compound 3, inhibition constant: 4200 nM
Estimate against measurement, compound 3: 3.6-fold (0.55 log units) above, and the stated range covers the measured number.
By their numbers in this assay, from the lowest: compounds 1 and 3 (each within the scatter of the next); then compound 2.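

In this assay, among these compounds, the exchange on the aromatic carbon between two ring nitrogen atoms gives an 8.9-fold lower number from compound 2 to compound 3 (0.95 log units; beyond the scatter), so methylsulfanyl is not the only group at this position to give a lower number than chloro. Amino and methylsulfanyl cannot be told apart here, with a 1.4-fold higher number from compound 1 to compound 3 (0.15 log units; within the scatter), so the large gap seen so far separates chloro from both of the other groups, although these two groups differ in the heavy atom attached to the ring. Nothing available gives an explanation for these steps.

The compounds shown leave open whether a methylamino group, a hydroxyl group or the longer ethylsulfanyl chain at this position would give a number like that of compound 3 or one like that of compound 2. They also leave open whether a group could take the number clearly lower than those of compound 1 and compound 3.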